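Bromo for Methoxy on the Aryl Substituent of Compound 2

The compounds below may be only part of what the source reports. "The series", "measured", "known", "first", "only" and "open" are said of these compounds alone.

Compound 2 `COc1ccc(-c2cc3ccc(OCCCCCn4cc(CNC(=O)CCCCC5CCSS5)nn4)cc3oc2=O)cc1` gives 34.5% in a functional assay on PC-12 cells (Rattus norvegicus) for cytotoxicity, read by MTT assay, with stated times of 3 h and 2 h, tested at 0.1 uM (on this read-out lower numbers stand for a weaker effect and higher numbers for a stronger effect at the one concentration tested), the lower of the two numbers in hand. For the measured compounds named here, compound 1 `O=C(CCCCC1CCSS1)NCc1cn(CCCCCOc2ccc3ccc(=O)oc3c2)nn1` gives 46.3% in this assay; the single measured step, a number 11.8 percentage points lower from compound 1 to compound 2 (beyond the scatter), introduced the 4-methoxyphenyl group onto the shared core. Compound 3 `O=C(CCCCC1CCSS1)NCc1cn(CCCCCOc2ccc3cc(-c4ccc(Br)cc4)c(=O)oc3c2)nn1` is not yet measured; it differs from compound 2 by bromo in place of methoxy on an aromatic carbon. Going by the values given here, no measured step exchanges one group for another on this phenyl ring, so the one step in hand, which added the whole ring rather than altering a group on it, bears only loosely on the change. With nothing pointing in either direction, compound 3 is expected to stay close in number to its parent, with an expected step of a number 0.5 percentage points higher from compound 2 to compound 3 (within the scatter) lying within the scatter. Compound 3 is therefore estimated at 35%, with a range from 22% to 48%.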

Compound 3, a percentage reported as activity, at one concentration (the size of the read-out at that concentration, not a potency): 41.8%
The estimate for compound 3 lay 6.8 percentage points below the measured number; the measured number falls inside the stated range.
By their numbers in this assay, from the lowest: compounds 2, 3 and 1 (each within the scatter of the next, the first and the last beyond it).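

In this assay, the first exchange made on this phenyl ring, rather than the addition of the ring itself, gives a number 7.3 percentage points higher from compound 2 to compound 3 (within the scatter) and so does not separate bromo from methoxy at this place. The earlier step, a number 11.8 percentage points lower from compound 1 to compound 2 (beyond the scatter), had suggested that an aryl group here shifts the number beyond the scatter, but a number 4.5 percentage points lower from compound 1 to compound 3 (within the scatter) shows that this does not hold for 4-bromophenyl, so compound 2 goes against any such pattern only on its own. No measurement in hand accounts for these numbers.

On these data alone, whether an amine or a carboxylic acid in place of bromo on this ring would move the number beyond the scatter remains open. So does whether these small differences would persist at any concentration other than the one tested.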